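This account rests on a few compounds, and the source may have more. Where it says the series, first, only, none or still open, it means among the compounds named here.

Compound 1, with the structure `CCCCn1cnc2c(Nc3cccc(Cl)c3)nc(NCOCc3ccc(/C=C/C(=O)Nc4ccccc4N)cc3)nc21`, reaches 30.4% in a functional assay on HepG2 cells (Homo sapiens) for antiproliferative activity, read by CCK-8 assay, with a stated time of 72 h, tested at 8 uM; a lower number here means a weaker effect, a higher number a stronger effect of the compound at the concentration tested. Compound 3, with the structure `CC(C)n1cnc2c(Nc3cccc(Cl)c3)nc(NCOCc3ccc(/C=C/C(=O)Nc4ccccc4N)cc3)nc21`, differs from it only by the change isopropyl in place of butyl on an aromatic nitrogen and gives 49.9%, a step of a number 19.5 percentage points higher from compound 1 to compound 3 (beyond the scatter). Compound 2, with the structure `CCCCn1cnc2c(NCc3ccc(C(=O)Nc4ccccc4N)cc3)nc(Cl)nc21`, carries a different core; how that core differs from the core of compound 1 is not broken down here. In this assay compound 2 gives 19.6%, the lowest of the three measured numbers. Compound 4, with the structure `CC(C)n1cnc2c(NCc3ccc(C(=O)Nc4ccccc4N)cc3)nc(Cl)nc21`, is made from compound 2 by the same change, (isopropyl in place of butyl on an aromatic nitrogen), at a place described in the same words. Because the same change gave a number 19.5 percentage points higher from compound 1 to compound 3 (beyond the scatter), a step of similar size is expected, though on a single example and a different core the expectation is loose: a number 13.4 percentage points higher from compound 2 to compound 4 (beyond the scatter). Compound 4 is therefore estimated at 33%, likely between 18% and 50%.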

Compound 4, a percentage reported as inhibition, at one concentration (the size of the read-out at that concentration, not a potency): 74.4%
Estimate against measurement, compound 4: 41.4 percentage points below; measured number above the stated range.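

Putting isopropyl in place of butyl on the aromatic nitrogen gives a number 54.8 percentage points higher from compound 2 to compound 4 (beyond the scatter) in this assay. The direction matches the earlier pair, but the size does not carry over from one core to the other: the same change on two cores in this assay, a number 19.5 percentage points higher (beyond the scatter) from compound 1 to compound 3 and a number 54.8 percentage points higher (beyond the scatter) from compound 2 to compound 4, 35.3 percentage points apart, beyond the scatter of two such steps. These two pairs show that the gain on one core is a poor guide to the gain on another, but they do not show why the cores differ or how a third core would respond.

Going by these compounds, it remains open whether an ethyl chain or a cyclopentyl ring on that nitrogen would give a higher or a lower number. Each number also comes from a single concentration and tells only whether the effect at that concentration is stronger or weaker.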